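Notes on compound 4 and a change at the chain end

The source may hold more compounds than are shown below. What is called first, only, known or untested is meant among the compounds shown, and "the series" means these compounds.

Measured in an assay on HEK293 cells for displacement of a labelled ligand from adenosine receptor A2b (Homo sapiens); on this read-out lower numbers stand for stronger inhibition and higher numbers for weaker inhibition:
compound 1 `CCCn1c(=O)c2[nH]c(Cc3ccccc3)nc2n(Cc2ccco2)c1=O` gives 117 nM
compound 2 `CCn1c(=O)c2c(nc(Cc3ccccc3)n2C)n(Cc2ccco2)c1=O` gives 12.9 nM
compound 3 `CCCn1c(=O)c2c(nc(Cc3ccccc3)n2C)n(Cc2ccco2)c1=O` gives 43.7 nM

Compound 3 stands second highest of the three numbers; it is reached by two modest steps, a 2.7-fold lower number from compound 1 to compound 3 (0.43 log units; beyond the scatter) and a 3.4-fold higher number from compound 2 to compound 3 (0.53 log units; beyond the scatter).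

Compound 4 `COCCn1c(=O)c2c(nc(Cc3ccccc3)n2C)n(Cc2ccco2)c1=O` differs from compound 3 by methoxy in place of methyl on a saturated chain carbon, two bonds along the chain from an aromatic nitrogen. Going by the values given here, of the measured steps only a 3.4-fold higher number from compound 2 to compound 3 (0.53 log units; beyond the scatter) touches the same chain carbon, and it added a methyl there rather than exchanging one for methoxy; no methyl-to-methoxy step exists in this set. Compound 4 in this assay is therefore expected to lie near compound 3, with no step beyond the scatter, a 1.1-fold lower number from compound 3 to compound 4 (0.04 log units; within the scatter). Compound 4 is estimated at 40 nM, range 12 nM to 130 nM.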

Compound 4, inhibition constant: 61.7 nM
Compound 4: middle estimate off by 1.5-fold (0.19 log units), on the low side; the measured number falls inside the stated range.
By their numbers in this assay, from the lowest: compound 2; then compounds 3, 4 and 1 (each within the scatter of the next, the first and the last beyond it).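

In this assay, methoxy in place of methyl at the chain end gives a 1.4-fold higher number from compound 3 to compound 4 (0.15 log units; within the scatter), so on this read-out the 2-methoxyethyl chain and the propyl chain cannot be told apart. Measured from the ethyl chain, methoxy on the same carbon gives a 4.8-fold higher number from compound 2 to compound 4 (0.68 log units; beyond the scatter), which leaves compound 2 with the lowest number among the three chains. No measurement shown here accounts for these numbers.

Still open, going by these compounds, is whether an amine or a carboxylic acid at the chain end would stay near compound 3. A longer chain, such as 3-methoxypropyl, is also untested in this set.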